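The source may hold more compounds than are shown below. What is called first, only, known or untested is meant among the compounds shown, and "the series" means these compounds.

Compound 1 `COCCOCCOCc1ccc2c(Br)cc(Br)c(O)c2n1`: > 100000 nM (a limit)
Compound 2 `Oc1c(Br)cc(Br)c2ccc(CNc3ccccc3)nc12`: 100000 nM
Compound 3 `CCCCOCc1ccc2c(Br)cc(Br)c(O)c2n1`: not yet measured

Within the data shown here, in an ADME assay on HeLa cells (Homo sapiens) for cytotoxicity, read by LDH release, with a stated time of 24 h (on this read-out lower numbers stand for stronger inhibition and higher numbers for weaker inhibition), compound 2 gives 100000 nM, the only actual number so far. Compound 1 gives > 100000 nM, which is a limit of the assay. Compound 3 has butoxy in place of anilino on a saturated chain carbon bound to an aromatic carbon. Among the measured compounds shown here, no measured step is available as a guide, and no change beyond the scatter is expected in this assay: the expected no change at the digits printed from compound 2 to compound 3 (within the scatter) is small. Compound 3 is expected at 100000 nM, with an estimated range of 40000 nM to 200000 nM.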

Compound 3, half-maximal inhibitory concentration: > 50000 nM
Compound 3: no number, only a limit; the forecaster's own chance of this, stated with the estimate: 70%; the middle value is on the limit's open side.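

In this assay no step can be read from compound 2 or compound 1 to compound 3; compound 1 and compound 3 give limits only. The compounds shown leave open whether butoxy in place of anilino shifts the value at all.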